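The compounds below may be only part of what the source reports. "The series", "measured", "known", "first", "only" and "open" are said of these compounds alone.

Measured so far in a functional assay on the whole organism with Mus musculus as the target, in the maximal electroshock model, with a stated time of 30 min; on this read-out lower numbers stand for an effect already at smaller amounts and higher numbers for an effect only at larger amounts of compound: compound 1 `Cc1cccc(C)c1NC(=O)Nc1ccncc1` gives 30 mg/kg. Compound 2 `O=C(Nc1ccncc1)Nc1ccccc1Br` gives 100 mg/kg. Compound 3 `O=C(Nc1ccncc1)Nc1ccccc1C(F)(F)F` gives 100 mg/kg.

Compound 3 stands level with compound 2 at the digits shown, the two together the highest numbers of the three; compound 1 sits well below, beyond the scatter. Going by the values given here, the single measured step, no change at the digits printed from compound 2 to compound 3 (within the scatter), shows one group swapped for another at this position without any shift in the read-out. Compound 4 `CC(C)c1ccccc1NC(=O)Nc1ccncc1` differs from compound 3 by isopropyl in place of trifluoromethyl on an aromatic carbon. Among the compounds with values here, no measured step exchanges trifluoromethyl for an alkyl group; the only alkyl-bearing analogue, compound 1, gives the lowest number. A modest move toward smaller doses is therefore expected, a 1.7-fold lower number from compound 3 to compound 4 (0.22 log units; within the scatter), though the step may well fall within scatter. Compound 4 is estimated at 60 mg/kg, range 30 mg/kg to 130 mg/kg.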

Compound 4, minimum effective dose: 100 mg/kg
Beside the measured number, compound 4's estimate is 1.7-fold (0.22 log units) below it; the measured number falls inside the stated range.
By their numbers in this assay, from the lowest: compound 1; then compounds 2, 3 and 4 (each within the scatter of the next).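

Isopropyl in place of trifluoromethyl gives no change at the digits printed from compound 3 to compound 4 (within the scatter) and isopropyl in place of bromo gives no change at the digits printed from compound 2 to compound 4 (within the scatter). In this assay an alkyl group on this aromatic carbon, ortho to a large group, thus reads the same as bromo and trifluoromethyl, a match that the earlier single step could not show. No measurement is at hand that would explain this sameness. Open, going by these compounds, is whether an amine, a carboxylic acid or a longer chain on this carbon would also read the same. On these data alone, a single methyl group at this place remains equally open.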